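Pyridin-2-yl in place of 2-cyanophenyl on compound 2

The source may hold more compounds than are shown below. What is called first, only, known or untested is meant among the compounds shown, and "the series" means these compounds.

In a functional assay on K562 cells (Homo sapiens) for cytotoxicity, with a stated time of 72 h (on this read-out lower numbers stand for stronger inhibition and higher numbers for weaker inhibition), compound 1 (`CC1c2c(-c3ccncc3)c(-c3ccccc3C#N)nn2CC1(C)C`) gives 77000 nM as a measured number. Compound 2 (`CC1(C)Cc2c(-c3ccncc3)c(-c3ccccc3C#N)nn2C1`) stands at > 100000 nM in this assay and this is a limit of the assay, not a number. Compound 2 therefore has no measured number of its own (the limit of > 100000 nM in this assay, at which 1 of the 2 values shown sits).

Within the data shown here, the only measured step is an at least 1.2-fold higher number from compound 1 to compound 2 (0.11 log units; that floor lies within the scatter) and it is hydrogen in place of methyl on a saturated ring carbon.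

Compound 3 (`CC1(C)Cc2c(-c3ccncc3)c(-c3ccccn3)nn2C1`) carries pyridin-2-yl in place of 2-cyanophenyl on an aromatic carbon. Among the measured compounds shown here, no measured step touches that aromatic carbon, so no step beyond the scatter is expected in this assay on this evidence. The estimated step is a number no higher from compound 2 to compound 3 (the limit leaves the size open) and it remains only an expectation. For compound 3 the estimate is 100000 nM (expected range 40000 nM to 250000 nM).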

Compound 3, half-maximal inhibitory concentration: > 100000 nM
Compound 3: a limit, no number (the forecaster's own chance of this, stated with the estimate: 65%); the middle value sits exactly at the limit.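

In this assay compound 3 stands at > 100000 nM, which is a limit of the assay and not a number. Compound 2 also stands at a limit, so no step from compound 2 to compound 3 can be read: the limit of > 100000 nM in this assay, at which 2 of the 3 values shown sit.

The compounds shown leave open whether pyridin-2-yl in place of 2-cyanophenyl changes the number in this assay at all.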